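Replacing 4-chlorophenyl with 5,6-dichloropyridin-3-yl

A few compounds are considered here, and "the series" means these few. Any claim that something is new, unique, unknown or untested is made for them only; others in the source may bear on it.

In a functional assay on HeLa cells (Homo sapiens) for inhibition, with a stated time of 72 h (on this read-out lower numbers stand for an effect already at smaller amounts and higher numbers for an effect only at larger amounts of compound), compound 1 (`COc1cc(CNCc2ccncc2)ccc1OCc1ccc(C)cc1`) gives 5000 nM, while compound 2 (`COc1cc(CNCc2ccncc2)ccc1OCc1ccc(Cl)cc1`) gives 890 nM, the lower of the two numbers. Compound 3 (`COc1cc(CNCc2ccncc2)ccc1OCc1cnc(Cl)c(Cl)c1`) keeps the core of compound 2 and alters the group on a saturated chain carbon bound to an oxygen on an aromatic ring: 5,6-dichloropyridin-3-yl in place of 4-chlorophenyl on a saturated chain carbon bound to an oxygen on an aromatic ring. Among the compounds with values here, only one measured step bears on this, and only in part: a 5.6-fold lower number from compound 1 to compound 2 (0.75 log units; beyond the scatter), for chloro in place of methyl on an aromatic carbon. Within the data shown here, no measured step shows what a ring with a hetero atom does, or what a second chlorine does. With so little to go on, no large move is foreseen. In this assay the expected step is a 1.3-fold lower number from compound 2 to compound 3 (0.10 log units; within the scatter), which would lie within the scatter. Compound 3 is estimated at 700 nM, with an expected range of 200 nM to 2500 nM.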

Compound 3, half-maximal effective concentration: 220 nM
Beside the measured number, compound 3's estimate is 3.2-fold (0.50 log units) above it, and the stated range covers the measured number.
By their numbers in this assay, from the lowest: compound 3; then compound 2; then compound 1.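

In this assay the exchange of 4-chlorophenyl for 5,6-dichloropyridin-3-yl on a saturated chain carbon bound to an oxygen on an aromatic ring gives a 4.0-fold lower number from compound 2 to compound 3 (0.61 log units; beyond the scatter) and so shows that this position accepts a ring with a hetero atom and a second chlorine, with a further fall in the number. Set against 4-methylphenyl, the same group gives a 23-fold lower number from compound 1 to compound 3 (1.36 log units; beyond the scatter) and widens the modest step seen so far into a large one. Nothing measured here explains why the number falls.

The ring nitrogen and the second chlorine entered together, and their shares stay apart only with a dichlorophenyl or a chloropyridinyl group, neither of which is among the compounds shown. Also open, as far as these compounds go, is how an amine or a carboxylic acid on this ring would compare.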